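Moving the Ring Nitrogen in an Amide-Linked Quinoline Series

The source may report more compounds than this note shows. Statements on the series, on what has been measured and on what is new or still open speak of the compounds shown alone.

Compound 1, `COc1ccc(C(=O)NCCNc2nc3cc(C)cc(C)c3cc2C#N)cc1`: 3000 nM
Compound 2, `Cc1cc(C)c2cc(C#N)c(NCCNC(=O)c3ccccn3)nc2c1`: "not active" (no number reported)

The two measured compounds share a core and differ only in the aryl group on the amide carbonyl. In an in vitro assay on FRT cells with Cystic fibrosis transmembrane conductance regulator variant F508del (Homo sapiens) as the target, read by fluorescence, with a stated time of 24 h, at 37 degrees C, in the presence of a further agent that is not named here (a lower number here means that less compound is needed, a higher number that more compound is needed for the effect), compound 1 gives 3000 nM. Among the measured compounds shown here, compound 2, which carries a pyridin-2-yl on that carbonyl, is reported in this assay as "not active" (no number reported), so no single number stands for it, and its distance from compound 1 cannot be put in figures; what the two values show is only that compound 1 has a measurable effect and compound 2 does not.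

Compound 3, `Cc1cc(C)c2cc(C#N)c(NCCNC(=O)c3cccnc3)nc2c1`, differs from compound 2 by pyridin-3-yl in place of pyridin-2-yl on a carbonyl carbon. With no numbered step available for this pair, the size of the change in this assay cannot be read from the data. Since compound 2 has no number, any measurable effect for compound 3 would already be an improvement over it, though the outcome could also again be no effect at all.

Compound 3 is estimated in this assay at 10000 nM, expected to fall between 3000 nM and 30000 nM.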

Compound 3, half-maximal effective concentration: 2700 nM
For compound 3 the middle estimate is 3.7-fold (0.57 log units) above the measured one; measured number below the stated range.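

Within this assay, moving the ring nitrogen on this carbonyl substituent separates a reported lack of activity from a measurable effect: compound 2, with pyridin-2-yl, has no number, whereas compound 3, with pyridin-3-yl, gives 2700 nM, although the size of that step cannot be read. The result also shows that a 4-methoxyphenyl group is not required for a measurable effect at this position, since replacing it with pyridin-3-yl gives a 1.1-fold lower number from compound 1 to compound 3 (0.05 log units; within the scatter). No available evidence accounts for the difference between the two pyridine isomers.

The compounds shown leave open whether pyridin-4-yl, the remaining isomer in this pyridine series, would give a measurable effect on this carbonyl carbon, and so whether compound 2 is a lone exception or part of a wider trend. They also leave open whether an unsubstituted phenyl, a pyridine bearing a methoxy group or a carboxylic acid on the ring, or a longer chain between the amide and the shared core would give a lower number than compound 3 at 2700 nM.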